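Swapping Fluoro for Chloro on an Amidine Biaryl Thiophene

The source may report more compounds than this note shows. Statements on the series, on what has been measured and on what is new or still open speak of the compounds shown alone.

Measured so far:
compound 1 `N=C(N)c1ccc(-c2ccc(-c3cc(Cl)cc(Cl)c3)s2)cc1` gives 454 nM
compound 2 `N=C(N)c1ccc(-c2ccc(-c3ccc(F)cc3)s2)cc1` gives 1610 nM
compound 3 `COc1cc(OC)cc(-c2ccc(-c3ccc(C(=N)N)c(F)c3)s2)c1` gives 1640 nM

The three compounds were tested in a functional assay on SK-OV-3 cells (Homo sapiens) for inhibition, read by sulforhodamine B assay, with a stated time of 48 h; on this read-out lower numbers stand for stronger inhibition of growth and higher numbers for weaker inhibition of growth. Among the three numbers, compound 2 stands second highest. Its value sits essentially on top of that of compound 3, a gap well within the usual scatter, so no order between compound 2 and compound 3 can be read from these data. Compound 1, by contrast, shows a clearly lower number, a gap beyond the scatter, so compound 1 inhibits growth more strongly than compound 2.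

Compound 4 `N=C(N)c1ccc(-c2ccc(-c3ccc(Cl)cc3)s2)cc1` is not yet measured. It differs from compound 2 in one place: chloro in place of fluoro on an aromatic carbon. Within the data shown here, no measured pair isolates this single change, so any expectation rests on the rough hint that compound 1, which carries two chloro groups, gives 454 nM against 1610 nM for compound 2. A modest step toward a lower number is therefore expected, a 1.7-fold lower number from compound 2 to compound 4 (0.23 log units; within the scatter), possibly no larger than the scatter. Compound 4 is estimated at 950 nM, within a range from 350 nM to 2600 nM.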

Compound 4, concentration for 50% growth inhibition: 246 nM
Beside the measured number, compound 4's estimate is 3.9-fold (0.59 log units) above it; measured number below the stated range.
By their numbers in this assay, from the lowest: compounds 4 and 1 (each within the scatter of the next); then compounds 2 and 3 (each within the scatter of the next).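

In this assay, among these compounds, the change from 4-fluorophenyl to 4-chlorophenyl gives a 6.5-fold lower number from compound 2 to compound 4 (0.82 log units; beyond the scatter), and this is the first pair here that isolates a single change. It shows that the carbon para to a large group is not indifferent to which halogen it carries. Exchanging one heavy atom for another, with no change in rings, hydrogen-bond donors, hydrogen-bond acceptors or net charge, is enough to give clearly stronger inhibition of growth, but nothing measured here explains why.

Still open, on these data alone, is whether bromo, methyl, an amine or a carboxylic acid on this same carbon would keep that gain, extend it or lose it. Also open, as far as these compounds go, is whether the same swap would give a step of similar size on a different core.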